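Hydroxy in Place of Fluoro: From Compound 1 to Compound 4

The compounds below may be only part of what the source reports. "The series", "measured", "known", "first", "only" and "open" are said of these compounds alone.

Compound 1 `O[C@@H](c1ccccc1)[C@H]1CO[C@H](c2ccccc2)[C@@H](C/C=C/c2cccc(F)c2)C1` was examined in a functional assay on HeLa cells (Homo sapiens) for cytotoxicity, read by WST assay, with a stated time of 48 h (a lower number here means a stronger inhibitor, a higher number a weaker inhibitor), where compound 1 gives 8380 nM. Two companions share its core. Compound 2 `COc1ccc(/C=C/C[C@H]2C[C@@H]([C@@H](O)c3ccccc3)CO[C@@H]2c2ccc(OC)c(OC)c2)cc1OC` gives 15500 nM in this assay, a number that lies within the scatter of compound 1, so the two cannot be ranked against each other. Compound 3 `COc1ccc(/C=C/C[C@H]2C[C@@H]([C@@H](OC(C)=O)c3ccc(OC)c(OC)c3)CO[C@@H]2c2ccc(OC)c(OC)c2)cc1OC` yields no number at all in this assay, only a limit of the assay, > 100000 nM. That reading stands at the limit of > 100000 nM in this assay, at which 1 of the 3 values shown sits. Of the two numbers actually reported, compound 1 holds the lower one, and its nearest neighbour is compound 2.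

Compound 4 `Oc1cccc(/C=C/C[C@H]2C[C@@H]([C@@H](O)c3ccccc3)CO[C@@H]2c2ccccc2)c1` differs from compound 1 in a single place: hydroxy in place of fluoro on an aromatic carbon. The change sits on an aromatic carbon of a six-membered aromatic ring of carbon only, meta to a large group. For the measured compounds named here, no measured pair repeats this exchange, so its size cannot be read from the data; the step from compound 1 to compound 4 is expected to be small, estimated as a 1.3-fold higher number from compound 1 to compound 4 (0.12 log units; within the scatter), and may not rise above the scatter. Compound 4 is therefore expected to give 11000 nM in this assay, with a likely range from 3500 nM to 35000 nM.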

Compound 4, half-maximal inhibitory concentration: 18600 nM
Compound 4: the middle estimate sits 1.7-fold (0.23 log units) below what was measured; the range from low to high includes it.
By their numbers in this assay, from the lowest: compounds 1, 2 and 4 (each within the scatter of the next, the first and the last beyond it). At a limit, above all of these: compound 3.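

Hydroxy in place of fluoro on an aromatic carbon is the first exchange here whose size can be read. For the compounds shown here, no earlier pair of compounds differed in only one place. In this assay, the change gives a 2.2-fold higher number from compound 1 to compound 4 (0.35 log units; beyond the scatter), a modest step that only just clears the scatter, so replacing this single atom at this place on the ring moves the reading by little, and compound 4 still gives a number rather than a limit of the assay. This rests on one pair alone and describes only this exchange on the core of compound 1, and no measurement shown here accounts for the direction or size of the step.

What the compounds shown leave open is how an amine or a carboxylic acid on the same aromatic carbon would read in this assay, and so whether the modest size of this step extends to groups other than fluoro and hydroxy. Also open, from the compounds shown here alone, is whether hydroxy in place of fluoro would give a similar step with a longer chain in place of the 3-(3-hydroxyphenyl)prop-2-en-1-yl group.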